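The source may hold more compounds than are shown below. What is called first, only, known or untested is meant among the compounds shown, and "the series" means these compounds.

Compound 1 `CCNC(=O)c1ccc(-c2cc3nnn(C4CCN(c5ncc(CC)cn5)CC4)c3cn2)c(C)c1`: < 90 nM
Compound 2 `CCNC(=O)c1ccc(-c2cc3nnn(C4CCN(c5ncc(CC)cn5)CC4)c3cn2)cc1C`: 1790 nM
Compound 3 `CCNC(=O)c1cc(C)c(-c2cc3nnn(C4CCN(c5ncc(CC)cn5)CC4)c3cn2)c(C)c1`: 1860 nM

The read-out is a physicochemical assay for solubility, read by HPLC, in phosphate buffer, measured as thermodynamic solubility, with a stated time of 24 h, at pH 6.8; a higher number here means a more soluble compound, a lower number a less soluble compound. Compound 1 gives < 90 nM, which is a limit of the assay rather than a number (the limit of < 90 nM in this assay, at which 1 of the 3 values shown sits). Compound 3 gives 1860 nM, and compound 2 gives 1790 nM; these two values sit within the scatter of each other. Compound 1 and compound 2 share the same atoms joined differently, and the difference between the two cores is not broken down here. From compound 1 to compound 3 the change is methyl in place of hydrogen on an aromatic carbon, and it produced an at least 20-fold higher number from compound 1 to compound 3 (1.31 log units; beyond the scatter). Compound 4 `CCNC(=O)c1c(C)cc(-c2cc3nnn(C4CCN(c5ncc(CC)cn5)CC4)c3cn2)cc1C` carries the same kind of change against compound 2: methyl in place of hydrogen on an aromatic carbon. The surroundings differ: in compound 3 the new methyl is ortho to a large group and meta to an ethylcarbamoyl group, whereas in compound 4 it is ortho to an ethylcarbamoyl group and meta to a large group. Since compound 2 already starts at 1790 nM rather than a limit, a smaller step is expected, a 1.7-fold higher number from compound 2 to compound 4 (0.22 log units; within the scatter). Compound 4 is estimated at 3000 nM, likely between 800 nM and 10000 nM.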

Compound 4, solubility: 5010 nM
The estimate for compound 4 lay 1.7-fold (0.22 log units) below the measured number, and the stated range covers the measured number.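

In this assay, methyl in place of hydrogen on an aromatic carbon gave a 2.8-fold higher number from compound 2 to compound 4 (0.45 log units; beyond the scatter), and the same kind of change on the other core gave an at least 20-fold higher number from compound 1 to compound 3 (1.31 log units; beyond the scatter), so the number rose on both cores shown. Compound 1 stands at a limit of the assay, not at a number, so the size of its step cannot be set against the newer one: the limit of < 90 nM in this assay, at which 1 of the 4 values shown sits. Two steps make no general rule, and since the new methyl also sits in a different place on each core, the effects of core and place cannot be separated.

The compounds shown leave open whether an amine or a carboxylic acid on that aromatic carbon would move the number the same way. They also leave open how the methyl change would read on any further core.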